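Aryl methyl on the compound 1 scaffold

The source may report more compounds than this note shows. Statements on the series, on what has been measured and on what is new or still open speak of the compounds shown alone.

Compound 1 `NCC(=O)NCc1nnc(-c2ccccc2)o1` is measured in an assay for inhibition of histone deacetylase 8 (Homo sapiens), read by fluorescence, with a stated time of 15 min (a lower number here means a stronger inhibitor, a higher number a weaker inhibitor), at 155 nM. Among the three measured compounds this is the highest number, though every gap to the others lies within the scatter: compound 2 `C[C@@H](N)C(=O)NCc1nnc(-c2ccccc2)o1` gives 98 nM and compound 3 `C[C@@H](N)C(=O)NCc1nnc(-c2ccc(F)cc2)o1` gives 116 nM. The step of a 1.6-fold lower number from compound 1 to compound 2 (0.20 log units; within the scatter) comes with methyl in place of hydrogen on a saturated chain carbon bound to an amine nitrogen and a carbonyl carbon. The step of a 1.2-fold higher number from compound 2 to compound 3 (0.07 log units; within the scatter) comes with fluoro in place of hydrogen on an aromatic carbon.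

Compound 4 `Cc1ccc(-c2nnc(CNC(=O)CN)o2)cc1` differs from compound 1 by methyl in place of hydrogen on an aromatic carbon. Within the data shown here, the nearest precedent is the aromatic substitution a 1.2-fold higher number from compound 2 to compound 3 (0.07 log units; within the scatter), which stayed within the scatter; the methyl addition a 1.6-fold lower number from compound 1 to compound 2 (0.20 log units; within the scatter) also stayed within the scatter, though on a chain carbon rather than a ring. Neither points to a change beyond the scatter in this assay. The expected step for compound 4 is a 1.0-fold lower number from compound 1 to compound 4 (0.01 log units; within the scatter). Compound 4 is therefore estimated at 150 nM, with a range from 75 nM to 300 nM.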

Compound 4, half-maximal inhibitory concentration: 139 nM
Estimate against measurement, compound 4: 1.1-fold (0.03 log units) above; measured number inside the range.
By their numbers in this assay, from the lowest: compounds 2, 3, 4 and 1 (each within the scatter of the next).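

In this assay, methyl in place of hydrogen on an aromatic carbon, para to a large group, gives a 1.1-fold lower number from compound 1 to compound 4 (0.05 log units; within the scatter), which extends the aromatic-ring readout to the compound 1 chain. The earlier ring step, a 1.2-fold higher number from compound 2 to compound 3 (0.07 log units; within the scatter), was a fluoro change on the compound 2 chain, so a carbon substituent and a halogen have now each been read on the ring, one on each chain, and both steps lie within the scatter. No measured evidence bears on why this step stays within the scatter.

Going by these compounds, whether a methoxy group, an amine, a carboxylic acid or a tert-butyl group on this aromatic carbon would give a step beyond the scatter remains open. Also open, on these data alone, is how the ring methyl behaves when combined with the chain methyl of compound 2.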